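Methoxy in place of bromo on the far phenyl ring

This account rests on a few compounds, and the source may have more. Where it says the series, first, only, none or still open, it means among the compounds named here.

Measured compounds:
compound 1 `O=[N+]([O-])c1ccc(CN2CCC(n3cc(CC(OCc4cc(-c5ccccc5)no4)c4ccc(Br)cc4)nn3)CC2)cc1`: > 25000 nM
compound 2 `COc1ccc(-c2cc(COC(Cc3cn(C4CCN(Cc5ccc([N+](=O)[O-])cc5)CC4)nn3)c3ccc(Br)cc3)on2)cc1`: > 25000 nM
compound 3 `O=[N+]([O-])c1ccc(CN2CCC(n3cc(CC(OCc4cc(-c5cccc(Br)c5)no4)c4ccc(Br)cc4)nn3)CC2)cc1`: > 25000 nM

Three compounds share one core and differ only in the substituent on the outer phenyl ring. In a functional assay on MDA-MB-231 cells (Homo sapiens) for cytotoxicity, with a stated time of 48 h (a lower number here means a stronger inhibitor, a higher number a weaker inhibitor), compound 1 reaches only a limit, > 25000 nM. Compound 2 likewise gives a limit, > 25000 nM. Compound 3 also stands at a limit, > 25000 nM, and so it cannot be placed above or below the other two. Because every value sits at the limit of > 25000 nM in this assay, at which 3 of the 3 values shown sit, the steps a step that the two limits leave unreadable from compound 1 to compound 2, a step that the two limits leave unreadable from compound 1 to compound 3 and a step that the two limits leave unreadable from compound 2 to compound 3 have no readable size.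

Compound 4 `COc1cccc(-c2cc(COC(Cc3cn(C4CCN(Cc5ccc([N+](=O)[O-])cc5)CC4)nn3)c3ccc(Br)cc3)on2)c1` has not yet been measured. Its difference from compound 3 is methoxy in place of bromo on an aromatic carbon. The measured steps bear on this change only in that no substituent on this ring, hydrogen, methoxy or bromo, has yet brought a compound off the limit. No step beyond the scatter is therefore expected, and the expected step is a step that the limit leaves unreadable from compound 3 to compound 4. Compound 4 is estimated at 30000 nM, within 10000 nM to 100000 nM, most likely reported again as a limit.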

Compound 4, half-maximal inhibitory concentration: > 25000 nM
Compound 4: a limit, no number; the forecaster's own chance of this, stated with the estimate: 85%; the middle value lies beyond the limit too.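

In this assay compound 4 gives > 25000 nM, which is again a limit. None of its steps from compound 1, compound 2 or compound 3 can be read: the limit of > 25000 nM in this assay, at which 4 of the 4 values shown sit. The compounds shown leave open whether any substituent on the outer phenyl ring brings the shared core off this limit.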